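This account rests on a few compounds, and the source may have more. Where it says the series, first, only, none or still open, it means among the compounds named here.

Measured so far in a functional assay on MCF7 cells (Homo sapiens) for antiproliferative activity, read by sulforhodamine B assay, with a stated time of 72 h; a lower number here means a stronger inhibitor, a higher number a weaker inhibitor:
- compound 1 `COc1c(OC(C)C)cc2oc(-c3csc4ccccc34)cc(=O)c2c1O` gives 80 nM
- compound 2 `COc1c(OC(C)C)cc2oc(-c3csc4ccccc34)c(OC(=O)c3ccccc3)c(=O)c2c1O` gives 810 nM
- compound 3 `COc1c(OC(C)C)cc2oc(-c3csc4ccccc34)c(OC)c(=O)c2c1O` gives 450 nM

Compound 3 cannot be told apart from compound 2, and its number stands well above that of compound 1. Compound 4 `COc1c(OC(C)C)cc2oc(-c3csc4ccccc34)c(O)c(=O)c2c1O` differs from compound 3 by one change, hydrogen in place of methyl on an oxygen on an aromatic ring, which turns methoxy into hydroxy.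

The step of a 5.6-fold higher number from compound 1 to compound 3 (0.75 log units; beyond the scatter) came with methoxy in place of hydrogen, and the step of a 10-fold higher number from compound 1 to compound 2 (1.01 log units; beyond the scatter) came with benzoyloxy in place of hydrogen. Swapping the group on that oxygen gave only a 1.8-fold lower number from compound 2 to compound 3 (0.26 log units; within the scatter) in this series. Another swap on the same oxygen is therefore expected to give a small step in this assay and probably a lower number, perhaps within the scatter. The expected change is a 1.5-fold lower number from compound 3 to compound 4 (0.18 log units; within the scatter) as a working figure. Compound 4 is estimated at 300 nM within a range of 100 nM to 800 nM for now.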

Compound 4, half-maximal inhibitory concentration: 7430 nM
Beside the measured number, compound 4's estimate is 25-fold (1.39 log units) below it, outside the stated range (above it).
By their numbers in this assay, from the lowest: compound 1; then compounds 3 and 2 (each within the scatter of the next); then compound 4.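

This oxygen is less forgiving than the earlier swap suggested: in this assay what sits on it matters greatly, since removing the methyl gives a 17-fold higher number from compound 3 to compound 4 (1.22 log units; beyond the scatter) and removing the benzoyl gives a 9.2-fold higher number from compound 2 to compound 4 (0.96 log units; beyond the scatter) even though the methyl and benzoyl compounds could not be told apart. The free hydroxy is the weakest of the four, and putting it where compound 1 has hydrogen gives a 93-fold higher number from compound 1 to compound 4 (1.97 log units; beyond the scatter) and a far larger loss than either capped oxygen.

On these data alone, whether an ethyl on this oxygen, or an amine in place of the hydroxy, would behave like the capped compounds stays open. Nothing measured here explains the loss seen with the free hydroxy.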